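The source may hold more compounds than are shown below. What is called first, only, known or untested is meant among the compounds shown, and "the series" means these compounds.

In an ADME assay on CCRF-CEM cells (Homo sapiens), read by XTT assay, with a stated time of 72 h (a lower number here means a stronger inhibitor, a higher number a weaker inhibitor), compound 3 (`O=C1C=CC(=O)C1=Cc1ccc(F)cc1`) gives 1600 nM and compound 1 (`O=C1C=CC(=O)C1=Cc1ccccc1`) gives 2600 nM and the two lie within the scatter of each other. Compound 2 (`COc1ccc(C=C2C(=O)C=CC2=O)cc1`) gives 3800 nM and only its gap to compound 3 exceeds the scatter: fluoro in place of methoxy on an aromatic carbon gives a 2.4-fold lower number from compound 2 to compound 3 (0.38 log units; beyond the scatter) in this series.

Compound 4 (`O=C1C=CC(=O)C1=Cc1ccc(Br)cc1`) differs from compound 3 by a single exchange, bromo in place of fluoro on an aromatic carbon, counted as bromo in place of fluoro on an aromatic carbon with the rest of the structure unchanged. For the measured compounds named here, no measured compound carries bromo, so the evidence is indirect. Fluoro in place of hydrogen gave a 1.6-fold lower number from compound 1 to compound 3 (0.21 log units; within the scatter) and methoxy in place of hydrogen gave a 1.5-fold higher number from compound 1 to compound 2 (0.16 log units; within the scatter) so neither group moved the number beyond the scatter from compound 1. Only the exchange between those two groups went further, and modestly. On that basis no step beyond the scatter is expected in this assay and the estimated change is a 1.2-fold higher number from compound 3 to compound 4 (0.07 log units; within the scatter) with no firm direction. Compound 4 is estimated at 1900 nM with an expected range from 900 nM to 4000 nM in this measurement.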

Compound 4, half-maximal inhibitory concentration: 1800 nM
For compound 4 the middle estimate is 1.1-fold (0.02 log units) above the measured one, within the range that was stated.
By their numbers in this assay, from the lowest: compounds 3, 4, 1 and 2 (each within the scatter of the next, the first and the last beyond it).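

In this assay, the result adds a second halogen at this position, on an aromatic carbon of a six-membered aromatic ring of carbon only, and bromo in place of fluoro gives a 1.1-fold higher number from compound 3 to compound 4 (0.05 log units; within the scatter), so the two halogens cannot be told apart here. Bromo in place of hydrogen gives a 1.4-fold lower number from compound 1 to compound 4 (0.16 log units; within the scatter), which leaves bromo, like fluoro and methoxy before it, without a step beyond the scatter from the unsubstituted compound, while bromo in place of methoxy gives a 2.1-fold lower number from compound 2 to compound 4 (0.32 log units; beyond the scatter), so the methoxy compound now lies beyond the scatter from both halogen compounds, and only modestly. Nothing in the data shown accounts for these small differences or for the modest gap to the methoxy compound.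

On these data alone, all four compounds differ only at this one position, so it remains open whether an amine or a carboxylic acid placed there would move the number beyond the scatter from hydrogen. As far as these compounds go, it also remains open whether the same exchanges would behave alike at another position on the ring or with a change to the rest of the shared core.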